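From methylamino to methyl: an estimate for compound 3

The source may report more compounds than this note shows. Statements on the series, on what has been measured and on what is new or still open speak of the compounds shown alone.

compound 1 `CNc1ncnc2c1c(-c1ccoc1)cn2[C@@H]1O[C@H](CO)[C@@H](O)[C@H]1O` – 96300 nM
compound 2 `C#Cc1cn([C@@H]2O[C@H](CO)[C@@H](O)[C@H]2O)c2ncnc(NC)c12` – 86000 nM

In an ADME assay on BJ cells (Homo sapiens), read by MTT assay, with a stated time of 72 h (a lower number here means a stronger inhibitor, a higher number a weaker inhibitor), compound 1 gives 96300 nM and compound 2 gives 86000 nM. These two numbers cannot be ranked, since the step of a 1.1-fold lower number from compound 1 to compound 2 (0.05 log units; within the scatter) does not rise above the ordinary noise of repeat measurements.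

Compound 3 `Cc1ncnc2c1c(-c1ccoc1)cn2[C@@H]1O[C@H](CO)[C@@H](O)[C@H]1O` keeps the core of compound 1 and its furan-3-yl group, and differs in one group: methyl in place of methylamino on an aromatic carbon. The methyl takes the place of methylamino on an aromatic carbon.

Going by the values given here, no measurement so far tests a change at this place. Among the compounds with values here, the only step available swaps furan-3-yl for ethynyl elsewhere on the molecule, so it offers no direct guide to the size of the new step. The data therefore support only a loose expectation. With compound 1 at a number as large as 96300 nM, there seems more room to move down than up, so a lower number is tentatively expected. The expected change is a 2.8-fold lower number from compound 1 to compound 3 (0.44 log units; beyond the scatter). For compound 3 the estimate is 35000 nM, with an expected range from 4000 nM to 120000 nM.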

Compound 3, half-maximal inhibitory concentration: 89200 nM
The estimate for compound 3 lay 2.5-fold (0.41 log units) below the measured number; low and high end bracket the measured number.
By their numbers in this assay, from the lowest: compounds 2, 3 and 1 (each within the scatter of the next).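

In this assay putting methyl in place of methylamino on this aromatic carbon gives a 1.1-fold lower number from compound 1 to compound 3 (0.03 log units; within the scatter) and so, in this first test of the position, the change has no readable effect on the number. This holds even though the group that leaves carries a hydrogen-bond donor and a hydrogen-bond acceptor and the group that enters carries neither, and the step joins a 1.1-fold lower number from compound 1 to compound 2 (0.05 log units; within the scatter) as a second single change to compound 1 that stays within the scatter. Nothing measured here explains why this step is so small.

Still open, as far as these compounds go, is whether this place responds to groups of another kind: a plain amine, a longer chain such as ethylamino, or a carboxylic acid on the same carbon could give a number that stands clear of the scatter, or could not. It also remains unknown whether the swap from methylamino to methyl would read the same with ethynyl in place of furan-3-yl, as the compounds shown test it only with the furan-3-yl group.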